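Fluoro for chloro: from compound 1 to compound 3

The source may hold more compounds than are shown below. What is called first, only, known or untested is meant among the compounds shown, and "the series" means these compounds.

Among the measured compounds shown here, compound 1 `CCOC(=O)C1=Cc2ccccc2OC1(OCc1cc(-c2ccc(Cl)cc2)no1)C(F)(F)F` in a functional assay on MCF7 cells (Homo sapiens) for inhibition, read by MTT assay, with a stated time of 24 h (a lower number here means a stronger inhibitor, a higher number a weaker inhibitor), gives 18200 nM, the only number measured. Compound 2 `O=C(O)C1=Cc2ccccc2OC1(OCc1cc(-c2ccc(F)cc2F)no1)C(F)(F)F` in this assay reaches only a limit of the assay, > 150000 nM. For the measured compounds named here, compound 2 and compound 1 share no single-place step, and no measured step of any kind is available. Compound 3 `CCOC(=O)C1=Cc2ccccc2OC1(OCc1cc(-c2ccc(F)cc2)no1)C(F)(F)F` differs from compound 1 by fluoro in place of chloro on an aromatic carbon. The expected step of a 1.6-fold higher number from compound 1 to compound 3 (0.22 log units; within the scatter) is a small weakening, hardly beyond the scatter. Compound 3 is therefore estimated at 30000 nM, with a range from 12000 nM to 80000 nM.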

Compound 3, half-maximal inhibitory concentration: 48200 nM
For compound 3 the middle estimate is 1.6-fold (0.21 log units) below the measured one; low and high end bracket the measured number.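

In this assay, among the compounds shown here, the change from 4-chlorophenyl to 4-fluorophenyl gives a 2.6-fold higher number from compound 1 to compound 3 (0.42 log units; beyond the scatter) and so provides the first single-place step. This aromatic position, para to a large group, therefore does not treat the two halogens alike, although the weakening with fluoro is only modest. Nothing available bears on the cause of this step. Still open, on these data alone, is how the same position responds to a methoxy group or an amine. With only chloro and fluoro compared here on the ethyl ester, no trend across substituents can be drawn.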